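The source may hold more compounds than are shown below. What is called first, only, known or untested is meant among the compounds shown, and "the series" means these compounds.

Compound 1 `C=C1C[C@]23C[C@@]1(O)CC[C@H]2c1cc2c(C(=O)O)coc2c(C)c1[C@@H]3C(=O)O`: > 10000 nM
Compound 2 `C=C1C[C@]23C[C@@]1(O)CC[C@H]2[C@@]12C=C[C@H](O)[C@@](C)(C(=O)O1)[C@H]2[C@@H]3C(=O)OC`: > 10000 nM

Both numbers come from a functional assay on RCK8 cells (Homo sapiens) for cytotoxicity, read by luminescence and CellTiter-Glo, with a stated time of 24 h; on this read-out lower numbers stand for stronger inhibition and higher numbers for weaker inhibition. For compound 1 the value > 10000 nM is a limit of the assay, not a number. For compound 2 the value > 10000 nM is likewise a limit. So compound 2 stands at the limit, (the limit of > 10000 nM in this assay, at which 2 of the 2 values shown sit), with no measured step to place it against. Compound 3 `C=C1[C@@H](O)[C@]23C[C@@]1(O)CC[C@H]2[C@@]12C=C[C@H](O)[C@@](C)(C(=O)O1)[C@H]2[C@@H]3C(=O)OC` differs from compound 2 by hydroxy in place of hydrogen on a saturated ring carbon. For the measured compounds named here, no comparable step has been measured, so no change beyond the scatter is expected in this assay. Compound 3 is therefore expected to show a step that the limit leaves unreadable from compound 2 to compound 3, giving an estimated 15000 nM, in the range 5000 nM to 50000 nM.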

Compound 3, half-maximal inhibitory concentration: > 10000 nM
Compound 3: no number, only a limit (the forecaster's own chance of this, stated with the estimate: 85%); the middle value does not contradict the limit.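

Compound 2 and compound 3 each give only a limit, so the change of hydrogen to hydroxy cannot be read as a step: the limit of > 10000 nM in this assay, at which 3 of the 3 values shown sit.

The compounds shown leave open whether that hydroxy changes cytotoxicity at all, and at what concentration any of them would act on these cells.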